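Swapping 3-fluorophenyl for phenethyl on a sulfur

The source may hold more compounds than are shown below. What is called first, only, known or untested is meant among the compounds shown, and "the series" means these compounds.

In a functional assay on SMMC-7721 cells (Homo sapiens) for inhibition, read by CCK-8 assay, with a stated time of 72 h, tested at 2 uM (on this read-out higher numbers stand for more inhibition of growth at the one concentration tested and lower numbers for less inhibition of growth), compound 2 `Nc1ccccc1NC(=O)c1ccc(CSc2cccc(F)c2)cc1` gives 18.6%. This is the middle of three numbers. Compound 1 `COc1ccc(SCc2ccc(C(=O)Nc3ccccc3N)cc2)cc1` gives 33.1%, and compound 3 `Nc1ccccc1NC(=O)/C=C/c1ccc(CSc2cccc3ccccc23)cc1` gives 3.7%, both beyond the usual scatter from compound 2.

The next molecule, compound 4 `Nc1ccccc1NC(=O)c1ccc(CSCCc2ccccc2)cc1`, carries phenethyl in place of 3-fluorophenyl on a sulfur. For the measured compounds named here, one measured step bears on this spot. It is a number 14.5 percentage points lower from compound 1 to compound 2 (beyond the scatter), a modest change that came with 3-fluorophenyl replacing 4-methoxyphenyl on a sulfur. So the group on the sulfur can shift the number, but that single step does not tell which way phenethyl will go. Compound 3 differs from compound 2 in more than one place and offers no clean comparison.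

With so little to go on, a small step within the scatter is expected, namely a number 3.6 percentage points lower from compound 2 to compound 4 (within the scatter). The estimated value for compound 4 is 15%, with an expected range from 3% to 32%.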

Compound 4, percent growth inhibition at one concentration: 28.1%
For compound 4 the middle estimate is 13.1 percentage points below the measured one; low and high end bracket the measured number.
By their numbers in this assay, from the lowest: compound 3; then compounds 2, 4 and 1 (each within the scatter of the next, the first and the last beyond it).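

In this assay, phenethyl on the sulfur gives a number 9.5 percentage points higher from compound 2 to compound 4 (within the scatter), while the comparison with the 4-methoxyphenyl compound gives a number 5 percentage points lower from compound 1 to compound 4 (within the scatter). Compound 4 therefore lies within the scatter of both compound 1 and compound 2, even though those two are separated by a step beyond the scatter, so its number cannot be grouped with either one. This position can carry an aromatic ring on a saturated chain, not only a ring such as 3-fluorophenyl, without a step beyond the scatter, but no data here explain this result.

The compounds shown leave open how a longer chain ending in the same ring would read. They also leave open whether an amine or a carboxylic acid in place of that ring would keep a comparable number.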